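A few compounds are considered here, and "the series" means these few. Any claim that something is new, unique, unknown or untested is made for them only; others in the source may bear on it.

Measured compounds: compound 1 `CC(C)n1ncc2c(C(=O)NCc3cn(-c4cccc(F)c4)nn3)cccc21` with 36100 nM; compound 2 `Cc1cccc(-n2cc(CNC(=O)c3cccc4c3cnn4C(C)C)nn2)c1` with 32300 nM; compound 3 `Cc1ccccc1-n1cc(CNC(=O)c2cccc3c2cnn3C(C)C)nn1` with 19200 nM.

All three were tested in a functional assay on PC-3 cells (Homo sapiens) for inhibition, read by MTT assay, with a stated time of 72 h; on this read-out higher numbers stand for weaker inhibition and lower numbers for stronger inhibition. Compound 3 gives the lowest of the three numbers, but its distance to the others is small: the step of a 1.7-fold lower number from compound 2 to compound 3 (0.23 log units; within the scatter) and the step of a 1.9-fold lower number from compound 1 to compound 3 (0.27 log units; within the scatter) both lie within the usual scatter, so no ordering among the three can be claimed. The difference between compound 2 and compound 3 is 2-methylphenyl in place of 3-methylphenyl on an aromatic nitrogen. Between compound 2 and compound 1 the change is fluoro in place of methyl on an aromatic carbon, and the step it made was a 1.1-fold higher number from compound 2 to compound 1 (0.05 log units; within the scatter), again within the scatter.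

Compound 4 `CC(C)n1ncc2c(C(=O)NCc3cn(-c4ccccc4F)nn3)cccc21` has not yet been measured in this assay. Its difference from compound 3 is fluoro in place of methyl on an aromatic carbon. Among the compounds with values here, this is the same kind of change as the one from compound 2 to compound 1, but not the same: in compound 4 the place is ortho to a large group, whereas in compound 1 it is meta to a large group. Since the earlier step of this kind, a 1.1-fold higher number from compound 2 to compound 1 (0.05 log units; within the scatter), was within the scatter, compound 4 is expected to stay close to compound 3, and the step of a 1.1-fold higher number from compound 3 to compound 4 (0.04 log units; within the scatter) is estimated to be small. Compound 4 is therefore expected to give about 21000 nM in this assay, most likely between 9000 nM and 48000 nM.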

Compound 4, half-maximal inhibitory concentration: > 40000 nM
Compound 4: no number, only a limit; the forecaster's own chance of this, stated with the estimate: 15%; at least 1.9-fold (0.27 log units) between middle value and limit.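

In this assay compound 4 gives > 40000 nM, which is a limit of the assay and not a number. Even so, fluoro in place of methyl on an aromatic carbon, ortho to a large group, produced an at least 2.0-fold higher number from compound 3 to compound 4 (0.31 log units; beyond the scatter), whereas the steps of an at least 1.2-fold higher number from compound 2 to compound 4 (0.09 log units; that floor lies within the scatter) and an at least 1.1-fold higher number from compound 1 to compound 4 (0.04 log units; that floor lies within the scatter) fix no order, as each gives only a floor within the scatter. This shows that on the core of compound 3 the change can move the number beyond the scatter, but it does not show that the change behaves differently from one core to the other: the same change on two cores in this assay, a 1.1-fold higher number (0.05 log units; within the scatter) from compound 2 to compound 1 and an at least 2.0-fold higher number (0.31 log units; beyond the scatter) from compound 3 to compound 4; the limit leaves it open whether they differ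

Going by these compounds, the size of the step to compound 4 remains open, and so does the question of whether the two steps of this kind truly part ways. On these data alone, with only methyl and fluoro compared on the six-membered aromatic ring, it is also open how a chloro, a methoxy or an amine group at the same place would behave in this assay.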